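Swapping the dichlorophenyl group on a growth inhibitor

This account rests on a few compounds, and the source may have more. Where it says the series, first, only, none or still open, it means among the compounds named here.

compound 1 `COc1cc(Nc2ncnc3c(NC(=O)Nc4cc(Cl)cc(Cl)c4)cccc23)cc(OC)c1`: 30.2 nM
compound 2 `COc1cc(Nc2ncnc3c(NC(=O)Nc4cc(C(F)(F)F)cc(C(F)(F)F)c4)cccc23)cc(OC)c1`: 467 nM

In a functional assay on RT-112 cells (Homo sapiens) for antiproliferative activity, read by MTT assay, with a stated time of 72 h (a lower number here means a stronger inhibitor of growth, a higher number a weaker inhibitor of growth), compound 1 holds the lower of the two numbers at 30.2 nM. Compound 2 sits at 467 nM, a gap well beyond the usual scatter. The next molecule, compound 3 `COc1cc(Nc2ncnc3c(NC(=O)Nc4ccc5c(c4)OCCO5)cccc23)cc(OC)c1`, has not yet been measured. It keeps the core of compound 1 and changes one group: 2,3-dihydro-1,4-benzodioxin-6-yl in place of 3,5-dichlorophenyl on an amide-type nitrogen. In words, 2,3-dihydro-1,4-benzodioxin-6-yl takes the place of 3,5-dichlorophenyl on an amide-type nitrogen. Among the compounds with values here, no measured compound carries this new group, so any forecast is loose. Within the data shown here, with compound 1 at 30.2 nM already the lower of only two values, a moderate rise in this assay is more likely than a fall. The estimated change is a 4.0-fold higher number from compound 1 to compound 3 (0.60 log units; beyond the scatter), towards weaker growth inhibition. For compound 3 the expected value is 120 nM, within an estimated range of 30 nM to 500 nM.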

Compound 3, concentration for 50% growth inhibition: 2750 nM
Beside the measured number, compound 3's estimate is 23-fold (1.36 log units) below it; the whole stated range lies below it.
By their numbers in this assay, from the lowest: compound 1; then compound 2; then compound 3.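

In this assay, the group on the amide-type nitrogen proves able to shift the result sharply: 2,3-dihydro-1,4-benzodioxin-6-yl in place of 3,5-dichlorophenyl gives a 91-fold higher number from compound 1 to compound 3 (1.96 log units; beyond the scatter), a large loss of growth inhibition. This change brings in a non-aromatic ring with 2 hetero atoms and 2 hydrogen-bond acceptors, features that 3,5-dichlorophenyl lacks, so this position does not accept every ring system equally. No measurement here explains why the step is so large.

The compounds shown leave open whether the loss follows from removing the two chlorines or from adding the oxygen-containing ring. An unsubstituted phenyl ring, or a phenyl ring carrying two methyl groups or two methoxy groups, could help separate these two parts of the change.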